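The source may report more compounds than this note shows. Statements on the series, on what has been measured and on what is new or still open speak of the compounds shown alone.

Compound 1 `Nc1nn(C(=O)Nc2ccc(Cc3ccccc3)cc2)c2ccccc12` and compound 2 `Nc1nn(C(=O)Nc2ccc(Cc3ccccc3)cc2)c2ccc(Cl)cc12` share one core and differ only where compound 2 carries chloro. In a functional assay on SF-295 cells (Homo sapiens) for antiproliferative activity, read by sulforhodamine B assay, with a stated time of 48 h (on this read-out higher numbers stand for weaker inhibition of growth and lower numbers for stronger inhibition of growth), compound 2 gives 24200 nM, the only number shown here. For compound 1 the assay reports only a limit, > 100000 nM, which matches (the limit of > 100000 nM in this assay, at which 1 of the 2 values shown sits). Among the compounds with values here, the step of an at least 4.1-fold lower number from compound 1 to compound 2 (0.61 log units; beyond the scatter) is the single measured step that bears on compound 3 `Nc1ccc2c(c1)c(N)nn2C(=O)Nc1ccc(Cc2ccccc2)cc1`, which differs from compound 2 by amino in place of chloro on an aromatic carbon. That step shows the group at this position can move the number, and amino is expected not to match chloro, so an estimated step of a 2.1-fold higher number from compound 2 to compound 3 (0.32 log units; beyond the scatter) is anticipated. Compound 3 is therefore expected to give 50000 nM, within 15000 nM to 150000 nM.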

Compound 3, concentration for total growth inhibition: 15100 nM
Compound 3: middle estimate off by 3.3-fold (0.52 log units), on the high side, within the range that was stated.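

In this assay, exchanging chloro for amino gives a 1.6-fold lower number from compound 2 to compound 3 (0.20 log units; within the scatter), so this change does not separate the two groups. Amino in place of hydrogen gives an at least 6.6-fold lower number from compound 1 to compound 3 (0.82 log units; beyond the scatter), which shows that the step away from hydrogen at this position is not confined to chloro. The value for compound 1 is a limit, so this step has no exact size: the limit of > 100000 nM in this assay, at which 1 of the 3 values shown sits.

On these data alone, it remains open whether a methoxy group, a nitrile or a carboxylic acid on this aromatic carbon would behave like chloro and amino. Also open, as far as these compounds go, is how far any group here can lower the number.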